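This account rests on a few compounds, and the source may have more. Where it says the series, first, only, none or still open, it means among the compounds named here.

Compound 3, whose structure is `CS(=O)(=O)c1ccccc1C(=O)N1CCC(N(C2CC2)S(=O)(=O)c2cccc(C(F)(F)F)c2)CC1`, stands highest of the three measured compounds in an assay on cells for inhibition of Voltage-dependent L-type calcium channel subunit alpha-1C (Homo sapiens), read by FLIPR and calcium flux, tested at 1 uM (a higher number here means a stronger effect of the compound at the concentration tested, a lower number a weaker effect), where compound 3 gives 19%. Its nearest neighbour is compound 2, `NC(=O)c1ccccc1C(=O)N1CCC(N(C2CC2)S(=O)(=O)c2cccc(C(F)(F)F)c2)CC1`, which in this assay gives 11%; the gap a number 8 percentage points higher from compound 2 to compound 3 (within the scatter) stays within the scatter. The lowest number belongs to compound 1, `NC(=O)c1ccc(C(=O)N2CCC(N(C3CC3)S(=O)(=O)c3cccc(C(F)(F)F)c3)CC2)cc1`, which in this assay gives 0%, and the step of a number 19 percentage points higher from compound 1 to compound 3 (beyond the scatter) lies beyond the scatter.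

Compound 4, `CN(C)c1cccc(C(=O)N2CCC(N(C3CC3)S(=O)(=O)c3cccc(C(F)(F)F)c3)CC2)c1`, differs from compound 3 only in the group on the carbonyl carbon: 3-(dimethylamino)phenyl in place of 2-(methylsulfonyl)phenyl on a carbonyl carbon.

Every measured step in this series changes that same group: a number 11 percentage points higher from compound 1 to compound 2 (beyond the scatter), a number 19 percentage points higher from compound 1 to compound 3 (beyond the scatter) and a number 8 percentage points higher from compound 2 to compound 3 (within the scatter). All are modest at most, and none of the three measured compounds reaches a strong effect, so swapping in 3-(dimethylamino)phenyl is not expected to produce a large change in either direction. Because compound 3 gives only 19%, the number for compound 4 is expected to remain low, and a small step of a number 9 percentage points lower from compound 3 to compound 4 (within the scatter) downward, within the scatter, is estimated. Compound 4 is therefore expected to give about 10%, between 0% and 25%.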

Compound 4, a percentage reported as inhibition, at one concentration (the size of the read-out at that concentration, not a potency): 40%
For compound 4 the middle estimate is 30 percentage points below the measured one, outside the stated range (above it).
By their numbers in this assay, from the lowest: compound 1; then compounds 2 and 3 (each within the scatter of the next); then compound 4.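

In this assay, going by these compounds alone, the group on the carbonyl carbon proves able to carry a much larger change than the earlier compounds suggested: 3-(dimethylamino)phenyl in place of 2-(methylsulfonyl)phenyl gives a number 21 percentage points higher from compound 3 to compound 4 (beyond the scatter), and the comparisons with the two carbamoylphenyl compounds give a number 29 percentage points higher from compound 2 to compound 4 (beyond the scatter) and a number 40 percentage points higher from compound 1 to compound 4 (beyond the scatter). All three steps are beyond the scatter, so compound 4 stands clearly highest of the four, and the earlier low numbers did not mark a limit on what this position can do while the rest of the molecule stays the same. The information available offers no explanation for why this group gives more than the other three.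

The names 3-(dimethylamino)phenyl and 2-(methylsulfonyl)phenyl show that both the group on the ring and its numbered place change at once, so the compounds shown cannot separate these two changes. Open, then, is whether the dimethylamino group itself matters or its place does, a question that 2-(dimethylamino)phenyl, 4-(dimethylamino)phenyl, 3-methoxyphenyl or unsubstituted phenyl at this position could help to answer.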